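This account rests on a few compounds, and the source may have more. Where it says the series, first, only, none or still open, it means among the compounds named here.

The compounds measured so far:
Compound 1, `CO[C@@H]1[C@@H](OC)[C@H](c2ccccc2)O[C@@H]2CO[C@@H](c3cccc(Cl)c3)O[C@@H]12`. In a functional assay on HEL cells (Homo sapiens) for cytotoxicity (a lower number here means that less compound is tolerated, a higher number that more compound is tolerated), compound 1 gives >= 40 ug/mL, which is a limit of the assay rather than a number.
Compound 2, `C=CCO[C@@H]1[C@@H](OCC=C)[C@H](c2ccccc2)O[C@@H]2CO[C@@H](c3ccccc3)O[C@@H]12`. In this assay compound 2 gives "not determined" (no result reported), that is, no result.
Compound 3, `CCCO[C@@H]1[C@@H](OCCC)[C@H](Cc2ccccc2)O[C@@H]2CO[C@@H](c3ccccc3)O[C@@H]12`. In this assay compound 3 gives "not determined" (no result reported), that is, no result.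

Compound 2 thus has no number of its own in this assay. Of the three compounds only compound 1 has a value at all, and that value is a limit. For the measured compounds named here, the single piece of evidence on hand is the limit of >= 40 ug/mL in this assay, at which 1 of the 3 values shown sits.

Compound 4, `C=CCO[C@@H]1[C@@H](OCC=C)[C@H](Cc2ccccc2)O[C@@H]2CO[C@@H](c3ccccc3)O[C@@H]12`, has not yet been measured. It differs from compound 2 in one place: benzyl in place of phenyl on a saturated ring carbon. Going by the values given here, compound 3 carries the same benzyl group on its saturated ring carbon but has no result in this assay, so no measured pair shows what this change does. Among the compounds with values here, with no measured step to lean on, the expected size of the step from compound 2 to compound 4 in this assay is none beyond the scatter, in either direction. Compound 4 is expected to give about 40 ug/mL in this assay, with a range from 20 ug/mL to 80 ug/mL, and most likely the result will again be only a limit.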

Compound 4, minimum cytotoxic concentration: 20 ug/mL
Estimate against measurement, compound 4: 2.0-fold (0.30 log units) above; low and high end bracket the measured number.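

In this assay compound 4 gives 20 ug/mL, but compound 2 and compound 3 have no result there, so no step can be read between compound 4 and either of them. The compounds shown leave open what benzyl in place of phenyl on the saturated ring carbon does to how much compound these cells tolerate.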